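A few compounds are considered here, and "the series" means these few. Any claim that something is new, unique, unknown or untested is made for them only; others in the source may bear on it.

Compound 1 `CC(=O)N[C@@H](CSC/C=C(\C)CC/C=C(\C)CCC=C(C)C)C(=O)CCl` and compound 2 `CC(C)=CCC/C(C)=C/CC/C(C)=C/CSC[C@H](NC(=O)OC(C)(C)C)C(=O)CCl` share one core, while compound 3 `CCCCCCCCCCCCSC[C@H](NC(C)=O)C(=O)CCl` and compound 4 `CCCCCCCCCCCCSC[C@H](NC(=O)OC(C)(C)C)C(=O)CCl` share another; the difference between the two cores is not broken down here. In a functional assay on MOLT-3 cells (Homo sapiens) (on this read-out lower numbers stand for stronger inhibition and higher numbers for weaker inhibition), compound 1 gives 1400 nM, and compound 2 gives 7700 nM. The change that separates them, (tert-butoxy in place of methyl on a carbonyl carbon), produced a 5.5-fold higher number from compound 1 to compound 2 (0.74 log units; beyond the scatter). In this assay compound 3 gives 2300 nM; set against compound 1 the two numbers lie within the usual scatter, whereas against compound 2 the number of compound 3 is the lower of the two. Compound 4 carries the same change, (tert-butoxy in place of methyl on a carbonyl carbon), since the surroundings of the place are described in identical words for both pairs. A step of similar size is therefore expected, and compound 4 is expected to show a 4.8-fold higher number from compound 3 to compound 4 (0.68 log units; beyond the scatter). This expectation rests on a single precedent, the step of a 5.5-fold higher number from compound 1 to compound 2 (0.74 log units; beyond the scatter), so it is held loosely. For compound 4 the estimated value in this assay is 11000 nM, with a likely range from 4500 nM to 28000 nM.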

Compound 4, half-maximal inhibitory concentration: 15500 nM
Compound 4: middle estimate off by 1.4-fold (0.15 log units), on the low side, and the stated range covers the measured number.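

In this assay, putting tert-butoxy in place of methyl on the carbonyl carbon gave a 6.7-fold higher number from compound 3 to compound 4 (0.83 log units; beyond the scatter), so the number rises on this core as it did on the core of compound 1. Within the data shown here, this rests on only two pairs in a single assay, so it does not show that the step would hold on other cores, and it says nothing about why the number rises. Within those limits, the change carried over from one core to the other with little difference in size, which means that the step seen on one of these two cores would have been a fair guide to the other: the same change on two cores in this assay, a 5.5-fold higher number (0.74 log units; beyond the scatter) from compound 1 to compound 2 and a 6.7-fold higher number (0.83 log units; beyond the scatter) from compound 3 to compound 4, 1.2-fold (0.09 log units) apart, within the scatter of two such steps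

On these data alone, only methyl and tert-butoxy appear on that carbonyl carbon, so it remains open how a group such as ethoxy, benzyloxy or phenyl would behave there. As far as these compounds go, it is also open whether the same step would appear on a core carrying a carboxylic acid or an amine.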